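The compounds below may be only part of what the source reports. "The series", "measured", "known", "first", "only" and "open" are said of these compounds alone.

Three compounds of this series have numbers in a functional assay on KB cells (Homo sapiens) for cytotoxicity, read by MTT assay, with a stated time of 72 h; on this read-out lower numbers stand for stronger inhibition and higher numbers for weaker inhibition. Compound 1 `O=C(NC(=S)NNc1ncnc2ccccc12)c1cccc(Cl)c1` gives 4740 nM and stands second highest of the three; compound 2 `COc1cc2ncnc(NNC(=S)NC(=O)c3cccc(Cl)c3)c2cc1OC` gives 4830 nM, and compound 3 `COc1cc2ncnc(NNC(=S)NC(=O)c3ccccc3Cl)c2cc1OC` gives 3560 nM, both within the scatter of compound 1. Among the measured compounds shown here, the one measured step, a 1.4-fold lower number from compound 2 to compound 3 (0.13 log units; within the scatter), changes only the aryl on the carbonyl carbon and stays within the scatter. Compound 4 `O=C(NC(=S)NNc1ncnc2ccccc12)c1ccc(F)cc1` differs from compound 1 in the same place: 4-fluorophenyl in place of 3-chlorophenyl on a carbonyl carbon. For the measured compounds named here, no measured step covers this exact exchange; the nearest guide is the aryl step from compound 2 to compound 3, which moved little. The step is therefore expected to be small, a 1.1-fold lower number from compound 1 to compound 4 (0.02 log units; within the scatter), in no sure direction. Compound 4 is estimated at 4500 nM, between 2000 nM and 10000 nM.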

Compound 4, half-maximal inhibitory concentration: 1870 nM
Beside the measured number, compound 4's estimate is 2.4-fold (0.38 log units) above it; measured number below the stated range.
By their numbers in this assay, from the lowest: compounds 4, 3, 1 and 2 (each within the scatter of the next, the first and the last beyond it).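

In this assay, the aryl on the carbonyl carbon now gives a step beyond the scatter: a 2.5-fold lower number from compound 1 to compound 4 (0.40 log units; beyond the scatter), with 4-fluorophenyl in place of 3-chlorophenyl. The earlier aryl step, a 1.4-fold lower number from compound 2 to compound 3 (0.13 log units; within the scatter), stayed within the scatter, so this position does respond to at least one aryl exchange, though only modestly. No evidence is available to explain the step.

The halogen and its place change together here, and the compounds shown do not separate the two. On these data alone, how an unsubstituted phenyl or a methoxyphenyl would read at this position stays open, as does whether 4-fluorophenyl gives a similar step on the core of compound 2.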